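The source may hold more compounds than are shown below. What is called first, only, known or untested is meant among the compounds shown, and "the series" means these compounds.

Measured compounds:
compound 1: `CC(C)c1cccc(C(C)C)c1NC(=O)NCC1(c2ccccc2)CCCCC1` — 21 nM
compound 2: `O=C(NCC1(c2ccccc2)CCCCC1)Nc1ccccc1` — 2300 nM

Two ureas that share a core were tested in an assay on microsomes from intestine for inhibition of acyl-CoA:cholesterol acyltransferase (Oryctolagus cuniculus); on this read-out higher numbers stand for weaker inhibition and lower numbers for stronger inhibition. Compound 2 gives 2300 nM, the higher of the two numbers, while compound 1 gives 21 nM; the gap between them lies well beyond the scatter of repeated measurements, so compound 2 is the weaker inhibitor of the pair.

Compound 3, `COc1ccccc1NC(=O)NCC1(c2ccccc2)CCCCC1`, has not yet been measured in this assay. It differs from compound 2 in one place: methoxy in place of hydrogen on an aromatic carbon. Going by the values given here, no measured pair shows this exact change, so the size of the step must be judged from the two compounds alone. Since compound 1, which carries groups on the same ring, gives the far lower 21 nM, compound 3 is expected to fall below compound 2, with a moderate step of a 3.3-fold lower number from compound 2 to compound 3 (0.52 log units; beyond the scatter) toward stronger inhibition. The expected value for compound 3 is 700 nM, within a range from 200 nM to 2500 nM.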

Compound 3, half-maximal inhibitory concentration: 270 nM
Estimate against measurement, compound 3: 2.6-fold (0.41 log units) above; measured number inside the range.
By their numbers in this assay, from the lowest: compound 1; then compound 3; then compound 2.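

In this assay, methoxy in place of hydrogen on an aromatic carbon, ortho to a large group, produces an 8.5-fold lower number from compound 2 to compound 3 (0.93 log units; beyond the scatter), a step toward stronger inhibition. Going by these compounds alone, this is the first change in one place with a measured size, and it shows that a single group at this position, adding one oxygen and one carbon to the phenyl of compound 2, is enough to move the number beyond the scatter. No measurement shown here bears on the reason for this step.

The compounds shown do not settle whether the oxygen of the methoxy matters, which a comparison with a methyl, an ethyl or a chlorine at the same position could address. They also leave open whether a longer chain such as ethoxy, or a second methoxy on the same ring, would carry the step further or reverse it.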